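Swapping a Nitrophenyl for an Allyl on the Ring Nitrogen

The source may hold more compounds than are shown below. What is called first, only, known or untested is meant among the compounds shown, and "the series" means these compounds.

Of the compounds shown here, three sharing one core have been measured in a functional assay on aorta with Alpha-1D adrenergic receptor (Rattus norvegicus) as the target; on this read-out lower numbers stand for an effect already at smaller amounts and higher numbers for an effect only at larger amounts of compound. Compound 1 `COc1ccc(Cc2nn(C(C)(C)C)c(=O)c3ccccc23)cc1OC` gives 10000 nM, and compound 2 `CCCCn1nc(Cc2ccc(OC)c(OC)c2)c2ccccc2c1=O` gives 5400 nM. Going by these compounds, compound 3 `COc1ccc(Cc2nn(-c3ccc([N+](=O)[O-])cc3)c(=O)c3ccccc23)cc1OC` gives only an assay limit, > 100000 nM, so it sits at the limit of > 100000 nM in this assay, at which 1 of the 3 values shown sits, and its true number is unknown. The steps of an at least 10-fold higher number from compound 1 to compound 3 (1.00 log units; beyond the scatter) and an at least 18-fold higher number from compound 2 to compound 3 (1.26 log units; beyond the scatter) both show the 4-nitrophenyl on this nitrogen giving a much higher number than either alkyl group. Compound 4 `C=CCn1nc(Cc2ccc(OC)c(OC)c2)c2ccccc2c1=O` carries allyl in place of 4-nitrophenyl on an aromatic nitrogen. A step of an at least 14-fold lower number from compound 3 to compound 4 (1.15 log units; beyond the scatter) is expected, roughly mirroring an at least 18-fold higher number from compound 2 to compound 3 (1.26 log units; beyond the scatter) in reverse, as allyl is a short chain like butyl. Compound 4 is therefore estimated at 7000 nM, with a range from 3000 nM to 20000 nM.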

Compound 4, half-maximal effective concentration: 9800 nM
For compound 4 the middle estimate is 1.4-fold (0.15 log units) below the measured one; the measured number falls inside the stated range.
By their numbers in this assay, from the lowest: compounds 2, 4 and 1 (each within the scatter of the next). At a limit, above all of these: compound 3.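

In this assay, the allyl group of compound 4 gives an at least 10-fold lower number from compound 3 to compound 4 (1.00 log units; beyond the scatter), so the high number does not extend to this short unsaturated chain. Allyl also cannot be told apart from the two saturated groups, with a 1.8-fold higher number from compound 2 to compound 4 (0.26 log units; within the scatter) and a 1.0-fold lower number from compound 1 to compound 4 (0.01 log units; within the scatter). Of the four groups on this nitrogen, only 4-nitrophenyl stands apart, and compound 3 gives only a limit, not a number: the limit of > 100000 nM in this assay, at which 1 of the 4 values shown sits.

Open, going by these compounds, is whether the aromatic ring or its nitro group goes with the high number, which a plain phenyl could separate. Also open, on these data alone, is whether a longer chain ending in an amine would move the number away from the values of the three alkyl and allyl compounds.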